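Notes on the aryl substituent of the saturated ring

The compounds below may be only part of what the source reports. "The series", "measured", "known", "first", "only" and "open" are said of these compounds alone.

Compound 2 `COc1cc(/C=C/C(=O)C2=C(/C=C/c3ccc(O)c(OC)c3)NC(=S)NC2c2ccccc2O)ccc1O` holds the higher of the two numbers recorded so far: in a functional assay, with a stated time of 20 min, tested at 50 uM (on this read-out higher numbers stand for a stronger effect at the one concentration tested and lower numbers for a weaker effect), compound 2 gives 88.5%. Compound 1 `COc1cc(/C=C/C(=O)C2=C(/C=C/c3ccc(O)c(OC)c3)NC(=S)NC2c2ccccc2)ccc1O` differs only by hydrogen where compound 2 carries a hydroxy on the aromatic carbon, and in this assay compound 1 gives 50.4%; the step of a number 38.1 percentage points higher from compound 1 to compound 2 (beyond the scatter) is the only one measured. Compound 3 `COc1cc(/C=C/C(=O)C2=C(/C=C/c3ccc(O)c(OC)c3)NC(=S)NC2c2ccc(N(C)C)cc2)ccc1O` has not been measured; it differs from compound 2 in that (4-(dimethylamino)phenyl in place of 2-hydroxyphenyl on a saturated ring carbon). For the measured compounds named here, the one step at hand bears on it directly, since the 2-hydroxyphenyl that made that large difference leaves and a group without a hydrogen-bond donor enters; the 4-(dimethylamino)phenyl, however, is not hydrogen, so a full return to the level of compound 1 is not certain. Compound 3 is therefore expected to lose activity in this assay, with an estimated step of a number 26.5 percentage points lower from compound 2 to compound 3 (beyond the scatter). The expected value for compound 3 is 62%, in an estimated range from 38% to 88%.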

Compound 3, a percentage reported as activity, at one concentration (the size of the read-out at that concentration, not a potency): 84%
The estimate for compound 3 lay 22 percentage points below the measured number, and the stated range covers the measured number.
By their numbers in this assay, from the lowest: compound 1; then compounds 3 and 2 (each within the scatter of the next).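

In this assay, the rise seen with the hydroxy group is not specific to that group: dimethylamino in place of hydrogen on the aromatic carbon also gives a large step, a number 33.6 percentage points higher from compound 1 to compound 3 (beyond the scatter). Exchanging 2-hydroxyphenyl for 4-(dimethylamino)phenyl, which has 0 hydrogen-bond donors, gives a number 4.5 percentage points lower from compound 2 to compound 3 (within the scatter), so among these three compounds a hydrogen-bond donor on this aryl group is not needed to stay clear of the level of compound 1. Nothing at hand accounts for the two substituted aryl groups reading alike.

Compound 2 and compound 3 differ in both the substituent and its place on the aromatic ring, so the two contributions cannot be separated. As far as these compounds go, whether a carboxylic acid or a methoxy group on this aromatic ring would also hold the read-out at this level remains open.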